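A few compounds are considered here, and "the series" means these few. Any claim that something is new, unique, unknown or untested is made for them only; others in the source may bear on it.

Compound 1 `O=C(CCCCC1CCSS1)Nc1ccc(Cl)cn1`: 48.5%
Compound 2 `O=C(CCCCC(S)CCS)Nc1cccc(Cl)c1`: 16.1%

In a functional assay on Bel-7402 cells (Homo sapiens) for inhibition, read by MTT assay, with a stated time of 24 h, tested at 100 ug/mL (on this read-out lower numbers stand for less inhibition of growth and higher numbers for more inhibition of growth at the one concentration tested), compound 2 gives 16.1% and compound 1 gives 48.5%. Compound 2 has the lower of the two numbers, and the gap between them lies beyond the scatter. Compound 3 `Cc1cccc(NC(=O)CCCCC(S)CCS)c1` differs from compound 2 in one place: methyl in place of chloro on an aromatic carbon, with methyl in place of chloro on an aromatic carbon. For the measured compounds named here, no measured pair shows this swap, so the expectation is cautious: no step beyond the scatter in this assay. The estimated a number 1.9 percentage points higher from compound 2 to compound 3 (within the scatter) is small. Compound 3 is expected at 18%, with an estimated range of 6% to 33%.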

Compound 3, percent growth inhibition at one concentration: 7.08%
Compound 3: the middle estimate sits 10.9 percentage points above what was measured, and the stated range covers the measured number.
By their numbers in this assay, from the lowest: compounds 3 and 2 (each within the scatter of the next); then compound 1.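

For the compounds shown here, with methyl in place of chloro on this aromatic carbon, the measurement in this assay shows a number 9 percentage points lower from compound 2 to compound 3 (within the scatter) and is the first direct test of a change at this position. At the one concentration tested, the two groups cannot be told apart, so swapping chloro for methyl here gives no clear change in growth inhibition. No measurement is available that bears on why this is so. As far as these compounds go, whether an amine or a carboxylic acid on the same carbon would give a step beyond the scatter stays open.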